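One methyl further along the chain of compound 3

A few compounds are considered here, and "the series" means these few. Any claim that something is new, unique, unknown or untested is made for them only; others in the source may bear on it.

Compound 1, `C=CCc1cc(C(C)=O)c(O)cc1OCCCCCCCCCCC#N`: in an assay on isolated protein for inhibition of leukotriene B4 receptor 1 (Homo sapiens), tested at 10 uM (a higher number here means more inhibition at the concentration tested (going by the name of the read-out), a lower number less inhibition), compound 1 gives 50%.
Compound 2, `C=CCc1cc(C(C)=O)c(O)cc1OCCCCC`: in this assay compound 2 gives 60%.
Compound 3, `C=CCc1cc(C(C)=O)c(O)cc1OCCCCCC`: in this assay compound 3 gives 50%.

Compound 3 stands level with compound 1, the two showing no change at the digits printed from compound 1 to compound 3 (within the scatter), and the step of a number 10 percentage points lower from compound 2 to compound 3 (within the scatter) is the other one that ends at compound 3. All three measured compounds share one core and differ only in the chain attached to the oxygen on the aromatic ring, and none of the steps among them leaves the scatter: a number 10 percentage points higher from compound 1 to compound 2 (within the scatter) as well.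

Compound 4, `C=CCc1cc(C(C)=O)c(O)cc1OCCCCCCC`, continues this series. It differs from compound 3 by methyl in place of hydrogen on a saturated chain carbon, six bonds along the chain from an oxygen on an aromatic ring. Among the measured compounds shown here, the closest precedent is the step from compound 2 to compound 3, the same kind of change one bond nearer the oxygen, which gave a number 10 percentage points lower from compound 2 to compound 3 (within the scatter). The replacement of the longer cyano-bearing chains by hydrogen, a number 10 percentage points higher from compound 1 to compound 2 (within the scatter) and no change at the digits printed from compound 1 to compound 3 (within the scatter), likewise stayed within the scatter. Compound 4 is therefore expected to show no step beyond the scatter, no change at the digits printed from compound 3 to compound 4 (within the scatter). In this assay compound 4 is estimated at 50%, with a range from 35% to 65%.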

Compound 4, a percentage reported as inhibition, at one concentration (the size of the read-out at that concentration, not a potency): 31%
Compound 4: middle estimate off by 19 percentage points, on the high side; the whole stated range lies above it.
By their numbers in this assay, from the lowest: compound 4; then compounds 1, 3 and 2 (each within the scatter of the next).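

In this assay methyl in place of hydrogen on a saturated chain carbon, six bonds along the chain from an oxygen on an aromatic ring, gives a number 19 percentage points lower from compound 3 to compound 4 (beyond the scatter) and so leaves the scatter, whereas the same change five bonds along gave a number 10 percentage points lower from compound 2 to compound 3 (within the scatter) and did not. The two other comparisons point the same way, with a number 29 percentage points lower from compound 2 to compound 4 (beyond the scatter) and a number 19 percentage points lower from compound 1 to compound 4 (beyond the scatter) placing compound 4 alone at the low end of the four compounds. The fall does not simply follow chain length, and compound 1 goes against any such reading: it carries a longer chain ending in a nitrile, yet in this assay compound 1 gives 50% and stands level with compound 3.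

Still open, on these data alone, is whether a longer unbranched chain than that of compound 4 would stay low, and whether an amine or a carboxylic acid at the end of that chain would read closer to compound 1 or to compound 4. Nothing further is at hand that bears on why inhibition falls at this position.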